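Replacing the Vinyl of Compound 3 with Carboxymethyl

The compounds below may be only part of what the source reports. "The series", "measured", "known", "first", "only" and "open" are said of these compounds alone.

Compound 3 `C=CCc1cc(Cl)c2oc(Cc3ccc(OC)cc3)c(C)c2c1O` gives the lowest number of the three in a functional assay for inhibition of Polyunsaturated fatty acid 5-lipoxygenase (Homo sapiens), in the absence of a further agent (a lower number here means a stronger inhibitor, a higher number a weaker inhibitor), at 20 nM. Compound 1 `COc1ccc(Cc2oc3c(Cl)cc(Cl)c(O)c3c2C)cc1` gives 860 nM in this assay, and compound 2 `CCOCc1cc(Cl)c2oc(Cc3ccc(OC)cc3)c(C)c2c1O` gives 291 nM. Compound 4 `COc1ccc(Cc2oc3c(Cl)cc(CCC(=O)O)c(O)c3c2C)cc1` differs from compound 3 by carboxymethyl in place of vinyl on a saturated chain carbon bound to an aromatic carbon. Going by the values given here, two measured steps bear on this site: a 43-fold lower number from compound 1 to compound 3 (1.63 log units; beyond the scatter) and a 15-fold lower number from compound 2 to compound 3 (1.16 log units; beyond the scatter), both large gains arriving at compound 3, whereas a 3.0-fold lower number from compound 1 to compound 2 (0.47 log units; beyond the scatter) was only modest. Among the compounds with values here, the step of a 15-fold lower number from compound 2 to compound 3 (1.16 log units; beyond the scatter) shows that the vinyl of compound 3 is the sole group at this chain carbon tied to a strong number, so exchanging it for carboxymethyl is expected to raise the number beyond the scatter, by roughly a 9.0-fold higher number from compound 3 to compound 4 (0.95 log units; beyond the scatter). Compound 4 is accordingly estimated at 180 nM, with a range from 45 nM to 700 nM.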

Compound 4, half-maximal inhibitory concentration: 2130 nM
The estimate for compound 4 lay 12-fold (1.07 log units) below the measured number, and the stated range ends below it.
By their numbers in this assay, from the lowest: compound 3; then compound 2; then compound 1; then compound 4.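

Going by these compounds alone, at this position, a chain ending in a carboxylic acid is the first change to raise the number in this assay. Carboxymethyl is poorer than vinyl (a 110-fold higher number from compound 3 to compound 4 (2.03 log units; beyond the scatter)) and ethoxy (a 7.3-fold higher number from compound 2 to compound 4 (0.86 log units; beyond the scatter)), and 2-carboxyethyl, unlike ethoxymethyl and allyl, is poorer than chloro (a 2.5-fold higher number from compound 1 to compound 4 (0.39 log units; beyond the scatter)). Compound 4 therefore has the highest number of the four, so this site does not simply favour any chain over chloro.

From the compounds shown here alone, whether the acid or the chain's length matters stays open, and a methyl ester, a primary amide or a plain propyl chain would bear on that. No evidence at hand accounts for this result.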